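The source may hold more compounds than are shown below. What is called first, only, known or untested is meant among the compounds shown, and "the series" means these compounds.

Values measured in an ADME assay on HaCaT cells (Homo sapiens) for cytotoxicity, read by MTT assay, with a stated time of 72 h; a higher number here means a weaker inhibitor, a lower number a stronger inhibitor
- compound 1 (`CCCCCCCCNC1=CC(=O)C=C(C[C@]2(C)[C@@H](C)CC[C@]3(C)C(C)=CCC[C@@H]23)C1=O`) gives 17000 nM
- compound 2 (`CCCCCCCCNC1=CC(=O)C=C(C(C)(C)C)C1=O`) gives 30000 nM

Compound 2 stands at 30000 nM in this assay, and compound 1 stands at 17000 nM. These two values lie within the usual scatter of each other, so this assay does not separate the two compounds.

Compound 3 (`CCNC1=CC(=O)C=C(C(C)(C)C)C1=O`) differs from compound 2 in one place: hydrogen in place of hexyl on a saturated chain carbon, two bonds along the chain from an amine nitrogen. Put simply, hydrogen stands in place of hexyl on a saturated chain carbon, two bonds along the chain from an amine nitrogen, so the chain is shorter.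

Within the data shown here, no two measured compounds differ in one place only, which leaves no direct guide to this change. A modest move towards a higher number, meaning weaker inhibition, is therefore expected, and it may stay close to the scatter.

For compound 3 the estimated value is 45000 nM, with an expected range from 15000 nM to 130000 nM. The expected change is a 1.5-fold higher number from compound 2 to compound 3 (0.18 log units; within the scatter).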

Compound 3, half-maximal inhibitory concentration: 30000 nM
For compound 3 the middle estimate is 1.5-fold (0.18 log units) above the measured one; measured number inside the range.
By their numbers in this assay, from the lowest: compounds 1, 2 and 3 (each within the scatter of the next).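

Swapping hexyl for hydrogen on a saturated chain carbon, two bonds along the chain from an amine nitrogen, gives no change at the digits printed from compound 2 to compound 3 (within the scatter) in this assay, and this is the first comparison here of compounds that differ in one place. At this position on this core, the hexyl portion of the chain can therefore be removed without the assay separating the two compounds. Nothing measured here explains this result.

This single pair cannot show whether the same would hold on the core of compound 1, which differs from compound 3 in more than one place. A longer chain, or a carboxylic acid or an amine carried on the chain, could still give a clearly different number at this position.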